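A methyl added to the chain: compound 3 to compound 4

The compounds below may be only part of what the source reports. "The series", "measured", "known", "first", "only" and "open" are said of these compounds alone.

Compound 1 `CCCCCCc1cc2cn([C@H]3C[C@H](O)[C@@H](CO)O3)c(=O)nc2o1`: 200000 nM
Compound 2 `CCCCCCCCc1cc2cn([C@H]3C[C@H](O)[C@@H](CO)O3)c(=O)nc2o1`: > 50000 nM
Compound 3 `CCCCCCCCCc1cc2cn([C@H]3C[C@H](O)[C@@H](CO)O3)c(=O)nc2o1`: > 200000 nM
Compound 4 `CCCCCCCCCCc1cc2cn([C@H]3C[C@H](O)[C@@H](CO)O3)c(=O)nc2o1`: not yet measured

In a functional assay on HEL cells (Homo sapiens) for cytotoxicity (a higher number here means that more compound is tolerated, a lower number that less compound is tolerated), compound 1 gives 200000 nM as a number. For compound 2 the reading is a limit of the assay, > 50000 nM. For compound 3 the reading is also a limit, > 200000 nM, so compound 3 sits at the limit of > 200000 nM in this assay, at which 1 of the 3 values shown sits. Among the measured steps, a step that the limit leaves unreadable from compound 1 to compound 2 and a step that the two limits leave unreadable from compound 2 to compound 3 cannot be sized, and a number no lower from compound 1 to compound 3 (the limit leaves the size open) shows only that tolerance did not fall. None of the three readings points to a loss of tolerance as the chain grows. Compound 4 differs from compound 3 by methyl in place of hydrogen on a saturated chain carbon, nine bonds along the chain from an aromatic carbon. Within the data shown here, the steps that bear on this change, a step that the two limits leave unreadable from compound 2 to compound 3 and a number no lower from compound 1 to compound 3 (the limit leaves the size open), give no readable size, and the chain-lengthening steps so far have not lowered the tolerated concentration. The account therefore expects no step beyond the scatter, a number no higher from compound 3 to compound 4 (the limit leaves the size open), and compound 4 is estimated at 200000 nM, within 100000 nM to 400000 nM, most likely reported again as a limit.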

Compound 4, minimum cytotoxic concentration: > 50000 nM
Compound 4: a limit, no number (the forecaster's own chance of this, stated with the estimate: 80%); the middle value is on the limit's open side.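

In this assay compound 4 gives > 50000 nM, which is a limit, so its steps from compound 1, compound 2 and compound 3 cannot be read. The compounds shown leave open whether lengthening the chain beyond that of compound 1 changes the tolerated concentration at all.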